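A few compounds are considered here, and "the series" means these few. Any claim that something is new, unique, unknown or untested is made for them only; others in the source may bear on it.

Compound 1 `Cn1ccc2ccc(-c3cc(Nc4ccccc4S(N)(=O)=O)cc4nccnc34)cc21`: 0.5 h
Compound 2 `Cn1ccc2ccc(-c3cc(Nc4ccccc4S(=O)(=O)Nc4cncnc4)cc4nccnc34)cc21`: 0.683 h

Both compounds were tested in an ADME assay on microsomes from liver (Mus musculus, strain CD-1) for metabolic stability, read by LC-MS, tested at 2 uM; a higher number here means that the compound lasts longer, a lower number that the compound disappears faster. In this assay compound 1 gives 0.5 h and compound 2 gives 0.683 h. Of these two numbers, compound 2 holds the higher one, but a 1.4-fold higher number from compound 1 to compound 2 (0.14 log units; within the scatter) lies within the scatter, so the two compounds cannot truly be set apart on this evidence.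

Compound 3 `Cn1ccc2ccc(-c3cc(Nc4ccccc4S(=O)(=O)NCC4CCOCC4)cc4nccnc34)cc21` has not yet been measured. It differs from compound 2 in one place: (oxan-4-yl)methyl in place of pyrimidin-5-yl on a sulfonamide nitrogen. Among the compounds with values here, only one measured step touches the same position, the sulfonamide nitrogen, and that is a 1.4-fold higher number from compound 1 to compound 2 (0.14 log units; within the scatter), which was within the scatter. Within the data shown here, no measured compound carries (oxan-4-yl)methyl, so nothing here speaks directly to that group. With a single step at this position and that step small, the expected outcome is a 1.1-fold lower number from compound 2 to compound 3 (0.06 log units; within the scatter), a step not beyond the scatter. Compound 3 is therefore estimated at 0.6 h, with a range from 0.3 h to 1.2 h.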

Compound 3, half-life: 0.3 h
Estimate against measurement, compound 3: 2.0-fold (0.30 log units) above; measured number inside the range.
By their numbers in this assay, from the lowest: compounds 3, 1 and 2 (each within the scatter of the next, the first and the last beyond it).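

At the sulfonamide nitrogen, the choice of group can matter in this assay: replacing pyrimidin-5-yl with (oxan-4-yl)methyl gives a 2.3-fold lower number from compound 2 to compound 3 (0.36 log units; beyond the scatter), a modest change, but the first at this position to clear the scatter. Measured against hydrogen on the same nitrogen, the (oxan-4-yl)methyl group gives a 1.7-fold lower number from compound 1 to compound 3 (0.22 log units; within the scatter), so neither substituent can be told apart from hydrogen, and the only clear separation at this position lies between the two substituents themselves. Nothing measured here explains why compound 3 and compound 2 differ.

The swap changes several things at once, turning an aromatic ring with two hetero atoms into a non-aromatic ring with one and placing a methyl link before that ring, and the compounds shown do not separate these changes. A phenyl group or a pyridinyl group on the sulfonamide nitrogen would test the aromatic side of the comparison, while an oxan-4-yl group without the link, or a cyclohexylmethyl group, would test the link and the ring oxygen.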